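A few compounds are considered here, and "the series" means these few. Any claim that something is new, unique, unknown or untested is made for them only; others in the source may bear on it.

Of the compounds shown here, three sharing one core have been measured in a functional assay on Ehrlich cells (Mus musculus) for cytotoxicity, tested at 25 ug/mL; a higher number here means a stronger effect of the compound at the concentration tested, a lower number a weaker effect. Compound 1, `COc1cc(N2C(N)=C(C#N)C(c3ccc([N+](=O)[O-])cc3)C3=C2CC(C)(C)CC3=O)cc(OC)c1OC`, gives 50%. Compound 2, `COc1cc(N2C(N)=C(C#N)C(c3c(O)ccc4ccccc34)C3=C2CC(C)(C)CC3=O)cc(OC)c1OC`, gives 10%. Compound 3, `COc1cc(N2C(N)=C(C#N)C(c3ccc(C)cc3)C3=C2CC(C)(C)CC3=O)cc(OC)c1OC`, gives 50%. On these numbers compound 3 stands level with compound 1, the two together forming the highest of the three values, while compound 2 lies well under both: a number 40 percentage points higher from compound 2 to compound 3 (beyond the scatter), and likewise a number 40 percentage points lower from compound 1 to compound 2 (beyond the scatter). Swapping the small group on the aromatic carbon, by contrast, left the read-out where it was: no change at the digits printed from compound 1 to compound 3 (within the scatter).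

Within the data shown here, compound 4 is `COc1cc(N2C(N)=C(C#N)C(c3ccccc3)C3=C2CC(C)(C)CC3=O)cc(OC)c1OC`. hydrogen in place of methyl on an aromatic carbon The step that bears most directly on this change is the one from compound 1 to compound 3, where methyl replaced nitro on the same aromatic carbon and the read-out did not move beyond the scatter. The two large steps involving compound 2 came from exchanging the whole ring on the saturated ring carbon, a different kind of change altogether. Removing the methyl in favour of hydrogen is therefore expected to leave this assay essentially unchanged, no change at the digits printed from compound 3 to compound 4 (within the scatter). For compound 4 the estimated value is 50%, within an expected range from 35% to 65%.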

Compound 4, a percentage reported as activity, at one concentration (the size of the read-out at that concentration, not a potency): 6%
The estimate for compound 4 lay 44 percentage points above the measured number; measured number below the stated range.
By their numbers in this assay, from the lowest: compounds 4 and 2 (each within the scatter of the next); then compounds 1 and 3 (each within the scatter of the next).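

The group on this aromatic carbon turns out to matter in this assay: with hydrogen in place of methyl the read-out collapses (a number 44 percentage points lower from compound 3 to compound 4 (beyond the scatter)), and hydrogen in place of nitro gives a step of the same size (a number 44 percentage points lower from compound 1 to compound 4 (beyond the scatter)). The earlier tie between nitro and methyl therefore did not mean that this carbon tolerates any change, since two quite different groups gave the same number, while losing a single carbon atom, 4-methylphenyl to phenyl, removed most of the read-out. Compound 4 also ends up level with the 2-hydroxynaphthalen-1-yl compound (a number 4 percentage points lower from compound 2 to compound 4 (within the scatter)), so this small edit matters as much here as exchanging the whole ring on the saturated ring carbon. Nothing measured here explains why hydrogen behaves so differently from the other two groups.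

An amine, a chlorine atom or a longer chain such as ethyl on this carbon would show whether almost any group restores the read-out or only some do. From the compounds shown here alone, with one tested concentration, it also remains open how compound 1 and compound 3 would compare across a range of concentrations.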